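Working notes on a three-compound cytotoxicity series

The compounds below may be only part of what the source reports. "The series", "measured", "known", "first", "only" and "open" are said of these compounds alone.

Measured so far:
compound 1 `COc1ccc(-c2cn(/N=C/c3cc4ccccc4nc3Cl)c(N)n2)cc1`: > 50000 nM, a limit of the assay, not a number.
compound 2 `Nc1nc(-c2ccc(Cl)cc2)cn1/N=C/c1cc2ccccc2nc1Cl`: > 50000 nM, likewise a limit.
compound 3 `COc1ccc(-c2cn(/N=C/c3cc4cc(C)ccc4nc3Cl)c(N)n2)cc1`: 25700 nM.

All three were run in a functional assay on DLD-1 cells (Homo sapiens) for cytotoxicity, read by MTT assay, with a stated time of 48 h; a higher number here means a weaker inhibitor, a lower number a stronger inhibitor. Compound 1 and compound 2 return no number there, only (the limit of > 50000 nM in this assay, at which 2 of the 3 values shown sit). The change between them, (chloro in place of methoxy on an aromatic carbon), therefore leaves a step that the two limits leave unreadable from compound 1 to compound 2. Among the measured compounds shown here, compound 3 differs from compound 1 by methyl in place of hydrogen on an aromatic carbon, which gives an at least 1.9-fold lower number from compound 1 to compound 3 (0.28 log units; that floor lies within the scatter); compound 3 holds the only readable number in this assay.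

Compound 4 `Cc1ccc2nc(Cl)c(/C=N/n3cc(-c4ccc(Cl)cc4)nc3N)cc2c1` is not yet measured. It differs from compound 3 by chloro in place of methoxy on an aromatic carbon, the same change as that from compound 1 to compound 2, here made on the core of compound 3, which carries the methyl described for compound 3.

Any expectation rests on compound 3 giving 25700 nM and on the earlier identical change reading as a step that the two limits leave unreadable from compound 1 to compound 2, which fixes no direction. The expected step is a 1.4-fold higher number from compound 3 to compound 4 (0.13 log units; within the scatter), small and toward a weaker inhibitor. For compound 4 the estimate is 35000 nM, expected between 15000 nM and 80000 nM, with a fair chance that only a limit is reported.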

Compound 4, half-maximal inhibitory concentration: 38900 nM
The estimate for compound 4 lay 1.1-fold (0.05 log units) below the measured number; low and high end bracket the measured number.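

Chloro in place of methoxy, read in this assay on the core that carries the methyl, gives a 1.5-fold higher number from compound 3 to compound 4 (0.18 log units; within the scatter). Methyl in place of hydrogen, read on the pair carrying chloro, gives an at least 1.2-fold lower number from compound 2 to compound 4 (0.10 log units; that floor lies within the scatter), and set beside the same change on the pair carrying methoxy this reads: the same change on two cores in this assay, an at least 1.9-fold lower number (0.28 log units; that floor lies within the scatter) from compound 1 to compound 3 and an at least 1.2-fold lower number (0.10 log units; that floor lies within the scatter) from compound 2 to compound 4; the limit leaves it open whether they differ. The step from methoxy to chloro on the core without the methyl cannot be read, so this change has one readable step only and nothing shows whether it carries from one core to the other, while the methyl change stands as two floors and not as two sizes: the limit of > 50000 nM in this assay, at which 2 of the 4 values shown sit.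

The compounds shown leave open how an amine or a carboxylic acid would read on the aromatic carbon that holds the methoxy or the chloro. They also leave open how a longer chain in place of the methyl would read in this assay.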